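Swapping the halophenyl ring on compound 2

This account rests on a few compounds, and the source may have more. Where it says the series, first, only, none or still open, it means among the compounds named here.

The measured compounds and their numbers in an ADME assay on microsomes from liver (Rattus norvegicus) for metabolic stability, read by LC-MS, in the presence of a further agent that is not named here (on this read-out lower numbers stand for slow clearance and higher numbers for fast clearance), are:
compound 1 `Cc1ncc(C)n2nc(-c3ccc4nc(-c5ccccc5)[nH]c4c3)nc12` gives 27.4 mL.min-1.g-1
compound 2 `Cc1ncc(C)n2nc(-c3ccn4cc(-c5cccc(Cl)c5)nc4n3)nc12` gives 18.9 mL.min-1.g-1
compound 3 `Cc1ncc(C)n2nc(-c3ccc4nc(-c5ccccn5)[nH]c4c3)nc12` gives 11.1 mL.min-1.g-1

Compound 2 holds the second highest of the three numbers; its number sits within the scatter of both compound 1 and compound 3. Going by the values given here, the only step among measured compounds is a 2.5-fold lower number from compound 1 to compound 3 (0.39 log units; beyond the scatter), which does not concern a halogen-bearing phenyl. Compound 4 `Cc1ncc(C)n2nc(-c3ccn4cc(-c5ccc(F)cc5)nc4n3)nc12` differs from compound 2 as follows: 4-fluorophenyl in place of 3-chlorophenyl on an aromatic carbon. Among the compounds with values here, no measured pair mirrors this change, so no step beyond the scatter is expected; the estimated step is a 1.1-fold lower number from compound 2 to compound 4 (0.05 log units; within the scatter). Compound 4 is estimated at 17 mL.min-1.g-1, with a range from 8.5 mL.min-1.g-1 to 34 mL.min-1.g-1.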

Compound 4, intrinsic clearance in microsomes: 3.1 mL.min-1.g-1
Compound 4: middle estimate off by 5.5-fold (0.74 log units), on the high side; the whole stated range lies above it.
By their numbers in this assay, from the lowest: compound 4; then compounds 3, 2 and 1 (each within the scatter of the next, the first and the last beyond it).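

In this assay the change on this aromatic carbon of the five-membered ring gives a 6.1-fold lower number from compound 2 to compound 4 (0.79 log units; beyond the scatter) even though both groups are halophenyl rings with the same count of heavy atoms. Going by these compounds alone, this position therefore responds to which halophenyl group it carries, something the earlier compounds could not show. Nothing measured here accounts for the step. 

The halogen and its place on the phenyl ring changed together, so the two remain unseparated. On these data alone, how a methoxy group or an amine on that ring would read also stays open.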